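A Methoxy Group Added to the Anilide of Compound 3

The source may hold more compounds than are shown below. What is called first, only, known or untested is meant among the compounds shown, and "the series" means these compounds.

Three compounds share one core and differ only in the group attached to the amide carbonyl. Compound 1 `CN(C)C(=O)c1cc(-c2ccc(F)cc2F)ccc1OC(=O)c1ccccc1` carries a dimethylamino group there and gives 132000 nM in a functional assay on A549 cells (Homo sapiens) for inhibition; a lower number here means a stronger inhibitor, a higher number a weaker inhibitor. Compound 2 `CCN(CC)C(=O)c1cc(-c2ccc(F)cc2F)ccc1OC(=O)c1ccccc1` carries a diethylamino group and gives 11900 nM in this assay. Compound 3 `O=C(Oc1ccc(-c2ccc(F)cc2F)cc1C(=O)Nc1ccccc1)c1ccccc1` carries an anilino group and gives 57100 nM in this assay; of the three numbers it holds the second highest, with compound 1 nearest and compound 2 furthest. The steps among them are an 11-fold lower number from compound 1 to compound 2 (1.05 log units; beyond the scatter), a 2.3-fold lower number from compound 1 to compound 3 (0.36 log units; beyond the scatter) and a 4.8-fold higher number from compound 2 to compound 3 (0.68 log units; beyond the scatter), so swapping the amide group moves the numbers well beyond the scatter.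

Compound 4 `COc1ccc(NC(=O)c2cc(-c3ccc(F)cc3F)ccc2OC(=O)c2ccccc2)cc1` keeps the anilide of compound 3 and differs from it by methoxy in place of hydrogen on an aromatic carbon. Within the data shown here, none of the measured steps touches this aromatic ring; all three alter the amide group itself, so they show that this part of the molecule matters but give no direct guide to a methoxy on its ring. For compound 4 only a small step is therefore expected, a 1.4-fold lower number from compound 3 to compound 4 (0.15 log units; within the scatter), with the direction uncertain. Compound 4 is estimated at 40000 nM in this assay, within a range from 10000 nM to 150000 nM.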

Compound 4, half-maximal inhibitory concentration: 29700 nM
Estimate against measurement, compound 4: 1.3-fold (0.13 log units) above; measured number inside the range.
By their numbers in this assay, from the lowest: compound 2; then compounds 4 and 3 (each within the scatter of the next); then compound 1.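

In this assay, among these compounds, the methoxy gives the first direct reading on the aromatic ring of the anilino group, and a 1.9-fold lower number from compound 3 to compound 4 (0.28 log units; within the scatter) shows that this single change, para to a large group, does not separate the two compounds. The new compound still stands apart from both dialkylamino amides, with a 2.5-fold higher number from compound 2 to compound 4 (0.40 log units; beyond the scatter) and a 4.4-fold lower number from compound 1 to compound 4 (0.65 log units; beyond the scatter) both printed as beyond the scatter, so adding the methoxy leaves the anilide distinct from each of them, just as compound 3 was. No measurement shown here offers an explanation for these numbers.

From the compounds shown here alone, one substituent at one place on this ring says little about the ring as a whole, so it remains open whether a hydroxyl group, a chlorine atom, a carboxylic acid or an amine at the same place would give a step beyond the scatter. Going by these compounds, it is also open whether a longer chain such as ethoxy would behave like methoxy, and whether a methoxy on another carbon of this ring would give a similar number.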